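From dicyanomethyl to (trifluoromethyl)carbonyl on a shared core

The source may hold more compounds than are shown below. What is called first, only, known or untested is meant among the compounds shown, and "the series" means these compounds.

In an ADME assay on microsomes from liver (Homo sapiens) for metabolic stability, read by LC-MS, using NADPH, tested at 3 uM (a lower number here means that the compound disappears faster, a higher number that the compound lasts longer), compound 1 `O=C(O)CC(c1ccccc1)c1c(-c2ccccc2)[nH]c2ccccc12` gives 1.05 h, and compound 2 `N#CC(C#N)C(c1ccccc1)c1c(-c2ccccc2)[nH]c2ccccc12` stands lower of the two at 0.437 h. Compound 3 `O=C(C(c1ccccc1)c1c(-c2ccccc2)[nH]c2ccccc12)C(F)(F)F` differs from compound 2 by (trifluoromethyl)carbonyl in place of dicyanomethyl on a saturated chain carbon bound to two aromatic carbons. Going by the values given here, the only measured step, a 2.4-fold lower number from compound 1 to compound 2 (0.38 log units; beyond the scatter), is modest and changes the group at the same place, but it involves a different replacement, so it offers only weak guidance and no large shift is expected. The estimated move is a 1.4-fold higher number from compound 2 to compound 3 (0.14 log units; within the scatter), which is not expected to exceed the scatter. For compound 3, the expected half-life is 0.6 h, with an estimated range of 0.22 h to 1.5 h.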

Compound 3, half-life: 0.852 h
Compound 3: middle estimate off by 1.4-fold (0.15 log units), on the low side; measured number inside the range.
By their numbers in this assay, from the lowest: compounds 2, 3 and 1 (each within the scatter of the next, the first and the last beyond it).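

On a saturated chain carbon bound to two aromatic carbons, (trifluoromethyl)carbonyl gives a 1.9-fold higher number from compound 2 to compound 3 (0.29 log units; within the scatter) and a 1.2-fold lower number from compound 1 to compound 3 (0.09 log units; within the scatter) in this assay. Compound 3 therefore cannot be separated from either compound 1 or compound 2, even though those two lie apart beyond the scatter. No supporting data explain these half-lives. On these data alone, whether an amine or a longer chain at this place would stay within the same span remains open, and so does whether these steps would hold on a core other than the shared one.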